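The source may report more compounds than this note shows. Statements on the series, on what has been measured and on what is new or still open speak of the compounds shown alone.

The shared core of compound 1 `CCC1(Cc2ccccc2)OS(=O)(=O)C=C1OCC#N` carries a varied group on the oxygen of the unsaturated carbon. In an ADME assay on HEL cells (Homo sapiens) for cytotoxicity, with a stated time of 3 days (a higher number here means that more compound is tolerated, a lower number that less compound is tolerated), compound 1 gives > 400000 nM, which is a limit of the assay. Compound 2 `CCC1(Cc2ccccc2)OS(=O)(=O)C=C1OCc1ccc(Cl)cc1` gives >= 50000 nM in this assay, also a limit. Compound 3 `CCC1(Cc2ccccc2)OS(=O)(=O)C=C1OCc1ccc(C(F)(F)F)cc1` gives >= 16000 nM in this assay, again a limit. The steps a step that the two limits leave unreadable from compound 1 to compound 2 and a step that the two limits leave unreadable from compound 2 to compound 3 therefore cannot be sized; compound 3 stands only at its limit. Compound 4 `CCC1(Cc2ccccc2)OS(=O)(=O)C=C1OCc1ccc(C)cc1` differs from compound 3 by methyl in place of trifluoromethyl on an aromatic carbon. Among the measured compounds shown here, no measured step gives a readable size for such a change, so no shift beyond the scatter is expected in this assay. Compound 4 is estimated at 30000 nM, range 8000 nM to 200000 nM, the expected step being a step that the limit leaves unreadable from compound 3 to compound 4.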

Compound 4, minimum cytotoxic concentration: >= 16000 nM
Compound 4 gave a limit, no number (the forecaster's own chance of this, stated with the estimate: 70%); the middle value does not contradict the limit.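

Among the compounds shown here, no step from compound 1, compound 2 or compound 3 to compound 4 can be read in this assay, as all four values are limits. The compounds shown leave open whether methyl, chloro and trifluoromethyl differ at all in this assay.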